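Replacing an Aminoalkyl Acyl Group with a Chlorophenoxy Acyl Group

The compounds below may be only part of what the source reports. "The series", "measured", "known", "first", "only" and "open" are said of these compounds alone.

Of the compounds shown here, two sharing a common core have been measured in an assay on HEK293 cells for displacement of a labelled ligand from Melanocortin receptor 4 (Homo sapiens); on this read-out lower numbers stand for stronger inhibition and higher numbers for weaker inhibition. Compound 1, `CC(C)C[C@H](N)c1ccccc1N1CCN(C(=O)[C@H](C)Cc2ccc(Cl)cc2F)CC1`, gives 67 nM. Compound 2, `CC(C)C[C@H](N)c1cc(C(F)(F)F)ccc1N1CCN(C(=O)CCNC2CCCCC2)CC1`, gives 4800 nM, the higher of the two numbers, and its nearest neighbour, compound 1, has a much lower number. The two compounds differ in several places, so the gap between them cannot be traced to a single change.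

Compound 3, `CC(C)C[C@H](N)c1cc(C(F)(F)F)ccc1N1CCN(C(=O)COc2cccc(Cl)c2)CC1`, has not yet been measured. It differs from compound 2 in one place: 3-chlorophenoxy in place of (cyclohexylamino)methyl on a saturated chain carbon bound to a carbonyl carbon. Among the compounds with values here, no step between measured compounds isolates this kind of change, so the expectation rests only on the two values known so far.

Within the data shown here, compound 3 is expected to give a lower number than compound 2, since the only other compound on the same core, compound 1, gives 67 nM, and the expected step is a 9.6-fold lower number from compound 2 to compound 3 (0.98 log units; beyond the scatter). For compound 3 the estimated value in this assay is 500 nM, with a range from 80 nM to 3000 nM.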

Compound 3, inhibition constant: 2600 nM
The estimate for compound 3 lay 5.2-fold (0.72 log units) below the measured number, and the stated range covers the measured number.
By their numbers in this assay, from the lowest: compound 1; then compounds 3 and 2 (each within the scatter of the next).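

In this assay, putting 3-chlorophenoxy in place of (cyclohexylamino)methyl on a saturated chain carbon bound to a carbonyl carbon gives a 1.8-fold lower number from compound 2 to compound 3 (0.27 log units; within the scatter) and this stays within the usual scatter, so the read-out does not separate the two groups at this place. This is the only pair shown that isolates a single change, and it shows that a non-aromatic ring carrying a hydrogen-bond donor on its chain and an aromatic ring with no such donor can stand at this place with no resolved difference in the number. Nothing measured here bears on why the two groups read alike.

Going by these compounds, it remains open whether the same exchange would also leave the number unresolved on the core of compound 1, which differs from compound 2 in several places and so cannot be read against this step. Also open, on these data alone, is how a carboxylic acid, a primary amine or a longer chain carrying the 3-chlorophenoxy group would read at this place in this assay on the shared core.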